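Compound 4: a dichlorophenyl amine variant of compound 3

The compounds below may be only part of what the source reports. "The series", "measured", "known", "first", "only" and "open" are said of these compounds alone.

Of the compounds shown here, three sharing one core have been measured in a functional assay on MDA-MB-231 cells (Homo sapiens) for inhibition, read by MTT assay, with a stated time of 72 h; on this read-out lower numbers stand for stronger inhibition and higher numbers for weaker inhibition. Compound 1 `O=C(CSc1nc(Nc2ccccc2)c2ccccc2n1)Nc1ccc(Cl)cc1` gives 17200 nM. Compound 2 `O=C(CSc1nc(Nc2ccccc2)c2ccccc2n1)Nc1ccc(C(F)(F)F)cc1` gives 11100 nM. Compound 3 `C=CC(=O)Nc1cccc(NC(=O)CSc2nc(Nc3cccc(Br)c3)c3ccccc3n2)c1` gives 19400 nM, the highest of the three numbers, though the gaps to compound 1 and compound 2 both fall inside the usual scatter of this assay, so no order among them can be read.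

Compound 4 `C=CC(=O)Nc1cccc(NC(=O)CSc2nc(Nc3ccc(Cl)cc3Cl)c3ccccc3n2)c1` is not yet measured. Compared with compound 3 it differs in one place: 2,4-dichlorophenyl in place of 3-bromophenyl on a nitrogen on an aromatic ring.

Among the compounds with values here, the only measured step, a 1.5-fold lower number from compound 1 to compound 2 (0.19 log units; within the scatter), concerns the aryl group on the amide nitrogen, not the aryl group on the aromatic-ring nitrogen that changes here; it therefore does not bear directly on the step to compound 4, and it was itself inside the scatter. Within the data shown here, with no step touching the (3-bromophenyl)amino to (2,4-dichlorophenyl)amino exchange, no shift beyond the scatter is expected: the step from compound 3 to compound 4 is estimated at a 1.1-fold lower number from compound 3 to compound 4 (0.06 log units; within the scatter). In this assay compound 4 is therefore expected to give 17000 nM, within a range from 7000 nM to 40000 nM.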

Compound 4, half-maximal inhibitory concentration: 23100 nM
For compound 4 the middle estimate is 1.4-fold (0.13 log units) below the measured one, and the stated range covers the measured number.
By their numbers in this assay, from the lowest: compounds 2, 1, 3 and 4 (each within the scatter of the next, the first and the last beyond it).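

In this assay, within the data shown here, the first measured exchange at this position, on a nitrogen on an aromatic ring, gives a 1.2-fold higher number from compound 3 to compound 4 (0.08 log units; within the scatter). Thus 3-bromophenyl and 2,4-dichlorophenyl cannot be told apart here, and moving from one halogen-bearing phenyl group to the other, with a different substitution pattern, leaves no readable shift. No measurement is available that could explain this result.

Going by these compounds, whether this position responds to a change of a different kind remains open, as both groups compared are halogen-bearing phenyl rings; a phenyl carrying a carboxylic acid or a methoxy group, or an aliphatic amine in place of the aryl group, would test this. On these data alone, it is also open whether the same exchange would read alike with a different group on the amide nitrogen.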